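This account rests on a few compounds, and the source may have more. Where it says the series, first, only, none or still open, it means among the compounds named here.

Working notes on the series, a functional assay on HepG2 cells (Homo sapiens) for inhibition, read by MTT assay, with a stated time of 48 h; on this read-out higher numbers stand for weaker inhibition and lower numbers for stronger inhibition.

Within the data shown here, compound 1 `O=C(CCCCc1ccccc1)Nc1ccc(N2CCN(c3ccc(OC[C@@H]4CO[C@@](Cn5cncn5)(c5ccc(Cl)cc5Cl)O4)cc3)CC2)cc1` gives 7010 nM in this assay, the lowest of the two numbers so far; the nearest is compound 2 `O=C(CCCc1ccccc1)Nc1ccc(N2CCN(c3ccc(OC[C@@H]4CO[C@@](Cn5cncn5)(c5ccc(Cl)cc5Cl)O4)cc3)CC2)cc1`, which gives 10800 nM, and the step of a 1.5-fold higher number from compound 1 to compound 2 (0.19 log units; within the scatter) stays within the scatter, so the two are not ordered.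

Compound 3 `Cc1ccc(C(=O)Nc2ccc(N3CCN(c4ccc(OC[C@@H]5CO[C@@](Cn6cncn6)(c6ccc(Cl)cc6Cl)O5)cc4)CC3)cc2)o1` is the next unmeasured member. Its difference from compound 1 is 5-methylfuran-2-yl in place of 4-phenylbutyl on a carbonyl carbon. Among the measured compounds shown here, the only measured step, from compound 1 to compound 2, is a shortening of the same chain by one carbon and moved the number by no more than the scatter; the replacement of the whole 4-phenylbutyl by a 5-methylfuran-2-yl is a larger change, on which no measured pair in this assay speaks. For the measured compounds named here, with no step to lean on, the expected number for compound 3 is kept near that of compound 1, with a wide range, giving an estimated step of a 1.1-fold higher number from compound 1 to compound 3 (0.06 log units; within the scatter). The estimate for compound 3 is 8000 nM, expected between 2000 nM and 32000 nM.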

Compound 3, half-maximal inhibitory concentration: 8700 nM
Compound 3: the middle estimate sits 1.1-fold (0.04 log units) below what was measured, and the stated range covers the measured number.
By their numbers in this assay, from the lowest: compounds 1, 3 and 2 (each within the scatter of the next).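

In this assay, 5-methylfuran-2-yl on the carbonyl carbon gives a 1.2-fold higher number from compound 1 to compound 3 (0.09 log units; within the scatter) against 4-phenylbutyl, and a 1.2-fold lower number from compound 2 to compound 3 (0.09 log units; within the scatter) against 3-phenylpropyl. The earlier pair spoke only to chain length, whereas these steps swap the whole group, from 10 heavy atoms with a six-membered aromatic ring of carbon only to 6 heavy atoms with a five-membered aromatic ring with 1 hetero atom, and the three compounds still cannot be ordered. No supporting data bear on why these numbers stay within the scatter of one another.

Going by these compounds, whether any group on this carbonyl carbon can separate from these three remains open. An amine, a carboxylic acid or a chain longer than 4-phenylbutyl would test this in this assay.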